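Trading 3,4-dimethoxyphenyl for 4-chlorophenyl

The source may report more compounds than this note shows. Statements on the series, on what has been measured and on what is new or still open speak of the compounds shown alone.

Compound 1 `COc1cc(-c2cccc3nc(-c4ccccc4)oc23)cc(OC)c1OC`: 20300 nM
Compound 2 `COc1ccc(-c2nc3cccc(-c4cc(OC)c(OC)c(OC)c4)c3o2)cc1OC`: 2800 nM
Compound 3 `COc1cc(-c2cccc3nc(-c4ccc(Br)cc4)oc23)cc(OC)c1OC`: > 25000 nM

In a functional assay on A549 cells (Homo sapiens) for antiproliferative activity, read by MTT assay, with a stated time of 48 h (on this read-out higher numbers stand for weaker inhibition and lower numbers for stronger inhibition), compound 2 stands lowest at 2800 nM, which makes it the strongest inhibitor of the three. For compound 3 the entry > 25000 nM is a limit of the assay, not a number.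

Compound 4 `COc1cc(-c2cccc3nc(-c4ccc(Cl)cc4)oc23)cc(OC)c1OC` has 4-chlorophenyl in place of 3,4-dimethoxyphenyl on an aromatic carbon of a five-membered aromatic ring with 1 nitrogen and 1 oxygen: 4-chlorophenyl in place of 3,4-dimethoxyphenyl on an aromatic carbon.

Going by the values given here, two measured steps bear most directly on this change. The swap to 4-bromophenyl gave an at least 8.9-fold higher number from compound 2 to compound 3 (0.95 log units; beyond the scatter), and the step between plain phenyl and 3,4-dimethoxyphenyl gave a 7.3-fold lower number from compound 1 to compound 2 (0.86 log units; beyond the scatter). Adding bromo to phenyl gave an at least 1.2-fold higher number from compound 1 to compound 3 (0.09 log units; that floor lies within the scatter), so a halogen on that ring shows no separable change here.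

In this assay a similar rise is therefore expected, beyond the scatter, as a 7.1-fold higher number from compound 2 to compound 4 (0.85 log units; beyond the scatter). For compound 4 the estimated value is 20000 nM, with an expected range from 9000 nM to 40000 nM.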

Compound 4, half-maximal inhibitory concentration: 5600 nM
For compound 4 the middle estimate is 3.6-fold (0.55 log units) above the measured one; the whole stated range lies above it.
By their numbers in this assay, from the lowest: compounds 2 and 4 (each within the scatter of the next); then compound 1. At a limit, above all of these: compound 3.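

In this assay, going by these compounds alone, 4-chlorophenyl on this carbon of the five-membered aromatic ring gives a 2.0-fold higher number from compound 2 to compound 4 (0.30 log units; within the scatter), so 3,4-dimethoxyphenyl is not the only group here that reaches this level. The earlier compounds shown here suggested that a halogen on the phenyl ring made no separable change, yet chloro in place of hydrogen gives a 3.6-fold lower number from compound 1 to compound 4 (0.56 log units; beyond the scatter) and chloro in place of bromo gives an at least 4.4-fold lower number from compound 3 to compound 4 (0.64 log units; beyond the scatter), so the choice of halogen matters, with compound 3 going against any rule that halogens help in general. The entry for compound 3 is a limit and not a number, so the step from it is only a floor: the limit of > 25000 nM in this assay, at which 1 of the 4 values shown sits.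

The compounds shown leave open whether fluoro on that phenyl ring would behave like chloro or like bromo. They also leave open how an amine or a carboxylic acid on that ring would fare.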